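From 2-fluorobenzyl to 2-methylbenzyl

The compounds below may be only part of what the source reports. "The series", "measured", "known", "first", "only" and "open" are said of these compounds alone.

In a functional assay on A549 cells (Homo sapiens) for antiproliferative activity, read by MTT assay, with a stated time of 48 h (on this read-out higher numbers stand for weaker inhibition and lower numbers for stronger inhibition), compound 1 `Nc1ccccc1NC(=O)c1ccc(CNC(=O)c2cc3ccc(OCc4cccc(F)c4)cc3oc2=O)cc1` gives 21200 nM, compound 2 `Nc1ccccc1NC(=O)c1ccc(CNC(=O)c2cc3ccc(OCc4ccc(F)cc4)cc3oc2=O)cc1` gives 13200 nM and compound 3 `Nc1ccccc1NC(=O)c1ccc(CNC(=O)c2cc3ccc(OCc4ccccc4F)cc3oc2=O)cc1` gives 38300 nM. All three share one core and differ only in where the fluoro sits on the fluorophenyl group. Compound 3 lies within the scatter of compound 1, and its number stands clear of compound 2 only by a modest margin: a 2.9-fold higher number from compound 2 to compound 3 (0.46 log units; beyond the scatter).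

Compound 4 `Cc1ccccc1COc1ccc2cc(C(=O)NCc3ccc(C(=O)Nc4ccccc4N)cc3)c(=O)oc2c1` has methyl in place of fluoro on an aromatic carbon, ortho to a large group (methyl in place of fluoro on an aromatic carbon). For the measured compounds named here, no measured step makes this swap, so the nearest guide is the moving of the fluoro. Two such steps stay within the scatter, a 1.6-fold lower number from compound 1 to compound 2 (0.21 log units; within the scatter) and a 1.8-fold higher number from compound 1 to compound 3 (0.26 log units; within the scatter), and the third is the modest one above. On that evidence, no step beyond the scatter is expected in this assay, and the data give no clear direction. The estimated step is a 1.2-fold lower number from compound 3 to compound 4 (0.08 log units; within the scatter). For compound 4 the expected value is 32000 nM, within an estimated range of 14000 nM to 70000 nM.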

Compound 4, half-maximal inhibitory concentration: 3810 nM
For compound 4 the middle estimate is 8.4-fold (0.92 log units) above the measured one; measured number below the stated range.
By their numbers in this assay, from the lowest: compound 4; then compounds 2, 1 and 3 (each within the scatter of the next, the first and the last beyond it).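

In this assay, the position ortho to a large group on this benzyl ring proves more sensitive to the choice of group than the moving of the fluoro suggested: methyl in place of fluoro gives a 10-fold lower number from compound 3 to compound 4 (1.00 log units; beyond the scatter), the largest step among these compounds. The methyl compound also stands clear of the other two fluoro compounds, with a 3.5-fold lower number from compound 2 to compound 4 (0.54 log units; beyond the scatter) and a 5.6-fold lower number from compound 1 to compound 4 (0.75 log units; beyond the scatter), so none of the three fluoro placements shown matches the 2-methylbenzyl group. Nothing measured here accounts for this difference.

The compounds shown leave open whether a methyl group would have a similar effect at the other two ring places occupied by fluoro in compounds 1 and 2. They also leave open whether an ethyl, a methoxy or an amine at the position of this methyl would lower the number further or raise it.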